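Sulfonamide to amide at the chain nitrogen

The source may hold more compounds than are shown below. What is called first, only, known or untested is meant among the compounds shown, and "the series" means these compounds.

Measured compounds:
compound 1 `COc1ccc(S(=O)(=O)NCCCNc2nccc(-c3c(-c4cccc(F)c4)nc4sccn34)n2)cc1`: 5510 nM
compound 2 `O=S(=O)(NCCNc1nccc(-c2c(-c3cccc(F)c3)nc3sccn23)n1)c1ccc(Cl)cc1`: 18600 nM
compound 3 `O=S(=O)(NCCNc1nccc(-c2c(-c3cccc(F)c3)nc3sccn23)n1)c1ccc(C(F)(F)F)cc1`: 7440 nM

In a functional assay on A-375 cells (Homo sapiens) for cytotoxicity, read by MTT assay (on this read-out higher numbers stand for weaker inhibition and lower numbers for stronger inhibition), compound 2 gives 18600 nM, the highest of the three numbers; compound 3 gives 7440 nM and compound 1 gives 5510 nM, both lower numbers, and both gaps to compound 2 lie beyond the scatter.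

Compound 4 `O=C(NCCNc1nccc(-c2c(-c3cccc(F)c3)nc3sccn23)n1)c1ccccc1` is not yet measured. Its difference from compound 2 is benzoyl in place of (4-chlorophenyl)sulfonyl on an amine nitrogen. Going by the values given here, the only measured step in the set, a 2.5-fold lower number from compound 2 to compound 3 (0.40 log units; beyond the scatter), changes a substituent on the aromatic ring of the sulfonyl group and keeps the sulfonyl itself, so it does not test the exchange of (4-chlorophenyl)sulfonyl for benzoyl on the amine nitrogen. Compound 1 differs from compound 2 in two places and gives no single-step reading either. Among the compounds with values here, no measured step therefore bears directly on compound 4; what can be said is that every measured change so far moved the number only modestly, and no measured compound falls far from the others.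

Given the lack of precedent, the step of a 1.6-fold lower number from compound 2 to compound 4 (0.19 log units; within the scatter) is expected to be small and in no certain direction, with a wide range. For compound 4 the estimate is 12000 nM, between 4000 nM and 40000 nM.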

Compound 4, half-maximal inhibitory concentration: 5060 nM
The estimate for compound 4 lay 2.4-fold (0.38 log units) above the measured number; low and high end bracket the measured number.
By their numbers in this assay, from the lowest: compounds 4, 1 and 3 (each within the scatter of the next); then compound 2.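

In this assay, the sulfonyl on the chain nitrogen proves not to be needed to keep the number low, since benzoyl in place of (4-chlorophenyl)sulfonyl gives a 3.7-fold lower number from compound 2 to compound 4 (0.57 log units; beyond the scatter). Going by these compounds alone, until now the only single-place step, a 2.5-fold lower number from compound 2 to compound 3 (0.40 log units; beyond the scatter), had varied the substituent on the aromatic ring and kept the sulfonyl, so this is the first reading of a change in the linking group itself, and it also lies beyond the scatter. The step removes the chloro along with the sulfonyl, so it reads as one combined exchange, and no measurement on hand accounts for it.

Still open, from the compounds shown here alone, is which part of that exchange carries the step: phenylsulfonyl on the same nitrogen, or a benzoyl group carrying chloro or trifluoromethyl on its ring, would separate the two. Also open, going by these compounds, is whether benzamido gives a similar number on the longer chain of compound 1, and whether a urea or a basic amine at the chain nitrogen fits the same trend.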